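This account rests on a few compounds, and the source may have more. Where it says the series, first, only, none or still open, it means among the compounds named here.

Measured compounds:
- compound 1 `COc1ccc2[nH]c(C(=O)N3CC(=O)N(Cc4ccccc4)[C@@H](CN4C(=O)c5ccccc5C4=O)C3)cc2c1`: > 100000 nM
- compound 2 `COc1ccc2[nH]c(C(=O)N3CC(=O)N(Cc4ccccc4)[C@@H](CN4[C@H](C)COC[C@@H]4C)C3)cc2c1`: > 100000 nM
- compound 3 `COc1ccc2[nH]c(C(=O)N3CC(=O)N(Cc4ccccc4)[C@@H](CN4CC5CCCCC5C4)C3)cc2c1`: 23800 nM

Among the compounds with values here, in a physicochemical assay for solubility, read by spectrophotometry, in phosphate buffer, with a stated time of 2 h, at pH 7.4 (a higher number here means a more soluble compound, a lower number a less soluble compound), compound 3 gives 23800 nM, the only actual number among the three values. Compound 1 returns only a limit, > 100000 nM. Compound 2 likewise returns only a limit, > 100000 nM. The two limits sit at the same point (the limit of > 100000 nM in this assay, at which 2 of the 3 values shown sit), so compound 3 stands at the low end of what is shown: an at least 4.2-fold lower number from compound 1 to compound 3 (0.62 log units; beyond the scatter) and an at least 4.2-fold lower number from compound 2 to compound 3 (0.62 log units; beyond the scatter) are both beyond the scatter, while a step that the two limits leave unreadable from compound 1 to compound 2 cannot be read.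

Compound 4 `COc1ccc2[nH]c(C(=O)N3CC(=O)N(Cc4ccccc4)[C@@H](CN4CCCc5ccccc54)C3)cc2c1` is not yet measured. Compared with compound 3 the change is a group of 10 heavy atoms (9 carbon, 1 nitrogen; one six-membered non-aromatic ring with 1 hetero atom, one six-membered aromatic ring of carbon only) in place of a group of 9 heavy atoms (8 carbon, 1 nitrogen; one five-membered non-aromatic ring with 1 hetero atom, one six-membered non-aromatic ring of carbon only), on a saturated chain carbon bound to a saturated ring carbon. Within the data shown here, the steps that touch the same position, an at least 4.2-fold lower number from compound 1 to compound 3 (0.62 log units; beyond the scatter) and an at least 4.2-fold lower number from compound 2 to compound 3 (0.62 log units; beyond the scatter), both run from a limit down to the number of compound 3, so they show only that the substituent at this position can move the reading by at least a modest amount; neither involves the group that enters here, and no step between two actual numbers exists. The expected step of a 1.5-fold higher number from compound 3 to compound 4 (0.17 log units; within the scatter) is therefore uncertain, with a small rise held as the more likely direction but a result within the scatter not excluded. Compound 4 is estimated at 35000 nM, in the range 10000 nM to 100000 nM.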

Compound 4, solubility: 8500 nM
For compound 4 the middle estimate is 4.1-fold (0.61 log units) above the measured one, and the stated range ends above it.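

In this assay, the position on a saturated chain carbon bound to a saturated ring carbon now has its first step between two actual numbers: with 1,2,3,4-tetrahydroquinolin-1-yl entering, the series shows a 2.8-fold lower number from compound 3 to compound 4 (0.45 log units; beyond the scatter). Against the other two groups the same entry gives an at least 11-fold lower number from compound 2 to compound 4 (1.07 log units; beyond the scatter), with 3,5-dimethylmorpholin-4-yl leaving, and an at least 11-fold lower number from compound 1 to compound 4 (1.07 log units; beyond the scatter), which places compound 4 at the low end of the four compounds. An aromatic ring in this group does not order the values by itself: compound 1 and compound 4 each carry a six-membered aromatic ring of carbon only yet stand at opposite ends, and compound 3, without one, stands between them.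

Compound 1 and compound 2 each return only a limit of the assay, so the step between them cannot be read and their true distance from compound 4 stays open: the limit of > 100000 nM in this assay, at which 2 of the 4 values shown sit. Also open is how a simple piperidine, or a group carrying a carboxylic acid, would read at this position in this assay, since no group of either kind appears among these compounds.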